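A few compounds are considered here, and "the series" means these few. Any claim that something is new, unique, unknown or untested is made for them only; others in the source may bear on it.

Measured compounds in a functional assay on RKO cells (Homo sapiens) for inhibition, read by MTT assay, with a stated time of 48 h; on this read-out lower numbers stand for stronger inhibition and higher numbers for weaker inhibition:
- compound 1 `COc1ccc(N(C)c2nc(C)nc3ccccc23)cc1C(=O)OCC[Se]C#N`: 2390 nM
- compound 2 `COc1ccc(N(C)c2nc(C)nc3ccccc23)cc1OCCCCCC[Se]C#N`: 1540 nM
- compound 3 `COc1ccc(N(C)c2nc(C)nc3ccccc23)cc1C(=O)OCCC[Se]C#N`: 1140 nM

Compound 3 gives the lowest number of the three. Against compound 2 the gap is within the scatter; against compound 1 it is a 2.1-fold lower number from compound 1 to compound 3 (0.32 log units; beyond the scatter), a modest separation. The steps of a 1.6-fold lower number from compound 1 to compound 2 (0.19 log units; within the scatter) and a 1.4-fold lower number from compound 2 to compound 3 (0.13 log units; within the scatter) both stay within the scatter, so the series is flat apart from the chain-lengthening step from compound 1 to compound 3.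

Compound 4 `COc1ccc(N(C)c2nc(C)nc3ccccc23)cc1C(=O)NCC[Se]C#N` differs from compound 3 as follows: a group of 6 heavy atoms (3 carbon, 2 nitrogen, 1 selenium; no ring) in place of a group of 7 heavy atoms (4 carbon, 1 nitrogen, 1 oxygen, 1 selenium; no ring), on a carbonyl carbon. Within the data shown here, no measured step isolates a change at the carbonyl carbon, so only the chain-length step bears on it: the group entering in compound 4 is the shorter chain, the direction that in the step from compound 1 to compound 3 went with the higher number. A modest rise toward the value of compound 1 is therefore expected, with wide uncertainty given the unmeasured change at the carbonyl carbon.

Compound 4 is expected to give 2100 nM in this assay, in the range 900 nM to 5000 nM. The expected step is a 1.8-fold higher number from compound 3 to compound 4 (0.27 log units; within the scatter).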

Compound 4, half-maximal inhibitory concentration: 1170 nM
Compound 4: middle estimate off by 1.8-fold (0.25 log units), on the high side; the range from low to high includes it.
By their numbers in this assay, from the lowest: compounds 3, 4, 2 and 1 (each within the scatter of the next, the first and the last beyond it).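

In this assay, the amide at the carbonyl carbon cannot be told apart from the longer ester of compound 3 (a 1.0-fold higher number from compound 3 to compound 4 (0.01 log units; within the scatter)) or from the ether-linked chain of compound 2 (a 1.3-fold lower number from compound 2 to compound 4 (0.12 log units; within the scatter)). Among these compounds, the only step here beyond the scatter is the modest 2.0-fold lower number from compound 1 to compound 4 (0.31 log units; beyond the scatter), where an amide nitrogen stands in place of the ester oxygen on a chain of the same length, so the higher number of compound 1 does not follow the shorter chain alone, as compound 4 carries that chain too. No measurement at hand accounts for these steps.

Still open, on these data alone, is whether a longer chain on the amide moves the number in either direction. Also open, as far as these compounds go, is how a carboxylic acid or a tertiary amide at the carbonyl carbon would compare with the ester and amide linkages.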